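The compounds below may be only part of what the source reports. "The series", "measured", "known", "first", "only" and "open" are said of these compounds alone.

Compound 1, `CSc1ccc2c(c1)c(O)c(C(=O)N(C)c1ccccc1)c(=O)n2C`, gives 67% in a functional assay on the whole organism for inhibition, with Mus musculus as the target, at a dose of 10 mg/kg by the oral route; a higher number here means more inhibition at the dose given (going by the name of the read-out), a lower number less inhibition.
Compound 2, `COc1cccc(N(C)/C(S)=C2/C(=O)c3cc(Cl)ccc3N(C)C2=O)c1`, gives 30% in this assay.
Compound 3, `CN1C(=O)/C(=C(/S)N(C)c2ccccc2)C(=O)c2cc(-n3cccc3)ccc21`, gives -10% in this assay.

Among the three measured compounds, compound 2 holds the middle place. Its nearest neighbour is compound 1, whose number is higher by a margin beyond the scatter, and its furthest is compound 3, whose number is lower, again beyond the scatter. No two of these compounds differ in only one place, so no single step has been measured between them; the values of compound 1, compound 2 and compound 3 show only that the read-out spans a wide range across quite different structures.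

Compound 4, `Cc1ccc(N(C)/C(S)=C2/C(=O)c3cc(Cl)ccc3N(C)C2=O)cc1`, has not been measured in this assay. It differs from compound 2 in one place: 4-methylphenyl in place of 3-methoxyphenyl on an amine nitrogen. Going by the values given here, nothing among the measured compounds shows how this swap of one aryl group for another on the amine nitrogen affects the read-out, and no measured step offers a size to lean on. Without such a guide, no step beyond the scatter is expected in this assay from the move to compound 4, and its direction is open. Compound 4 is therefore estimated at 30%, with a range from 5% to 55%. The step this estimate implies, no change at the digits printed from compound 2 to compound 4 (within the scatter), is expected to stay within the scatter.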

Compound 4, a percentage reported as inhibition, in the whole organism at one dose (the size of the read-out at that dose, not a potency): 23%
For compound 4 the middle estimate is 7 percentage points above the measured one; measured number inside the range.
By their numbers in this assay, from the lowest: compound 3; then compounds 4 and 2 (each within the scatter of the next); then compound 1.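

In this assay, the change from 3-methoxyphenyl to 4-methylphenyl on the amine nitrogen gives a number 7 percentage points lower from compound 2 to compound 4 (within the scatter), the first step measured at this position, and the two aryl groups cannot be told apart by this read-out. The swap removes the one hydrogen-bond acceptor counted on the leaving group and moves to a different substituent on the phenyl ring, yet the read-out stays within the scatter, so this pair gives no sign that the methoxy group is required at this dose. No available evidence explains this outcome, and the step alone does not separate the effect of the substituent from that of where it sits on the ring.

Open, going by these compounds, is whether an aryl ring carrying a carboxylic acid or an amine, or a cyclohexyl group in place of the aryl ring, would stay within the scatter of these two compounds. Also open, on these data alone, is whether this position contributes to the wider spread: compound 1 and compound 3 each differ from compound 2 and compound 4 in more than one place.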